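The compounds below may be only part of what the source reports. "The series", "measured", "known", "first", "only" and "open" are said of these compounds alone.

Measured so far in a functional assay on the whole organism for inhibition, with Rattus norvegicus as the target, read by paw edema, with stated times of 30 min and 2 h, at a dose of 0.28 mmol/kg by the oral route; on this read-out higher numbers stand for more inhibition at the one dose given (going by the name of the read-out) and lower numbers for less inhibition:
Compound 1 `CNC(=O)c1nc(-c2cc(OC)c(OC)c(OC)c2)n(-c2ccc(OC)cc2)n1`: 74%
Compound 2 `COc1ccc(-n2nc(C(=O)Nc3ccc(C(F)(F)F)cc3)nc2-c2cc(OC)c(OC)c(OC)c2)cc1`: 55%

Among the measured compounds shown here, compound 2 stands lowest of the two numbers; the one step that exists, a number 19 percentage points lower from compound 1 to compound 2 (beyond the scatter), is beyond the scatter. Compound 3 `COc1ccc(-n2nc(C(=O)Nc3ccccc3)nc2-c2cc(OC)c(OC)c(OC)c2)cc1` differs from compound 2 by hydrogen in place of trifluoromethyl on an aromatic carbon. For the measured compounds named here, no measured step removes a trifluoromethyl; the only step that bears on this part of the molecule is the loss seen from compound 1 to compound 2, and compound 3 keeps the phenyl on the amide nitrogen. A small move of compound 3 in this assay , a number 5 percentage points higher from compound 2 to compound 3 (within the scatter), is therefore expected, likely within the scatter. Compound 3 is estimated at 60%, between 45% and 75%.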

Compound 3, a percentage reported as inhibition, in the whole organism at one dose (the size of the read-out at that dose, not a potency): 51%
Compound 3: middle estimate off by 9 percentage points, on the high side; measured number inside the range.
By their numbers in this assay, from the lowest: compounds 3 and 2 (each within the scatter of the next); then compound 1.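

In this assay, hydrogen in place of trifluoromethyl on the aromatic carbon gives a number 4 percentage points lower from compound 2 to compound 3 (within the scatter), so this substituent does not separate the two compounds at this dose. Phenyl in place of methyl on the amide nitrogen gives a number 23 percentage points lower from compound 1 to compound 3 (beyond the scatter), which shows that the loss seen with the 4-(trifluoromethyl)phenyl group remains without the trifluoromethyl. No available evidence gives a cause for either step.

As far as these compounds go, it remains open whether a longer chain such as butyl on the amide nitrogen keeps the number of compound 1. Also open, from the compounds shown here alone, is whether an amine or a carboxylic acid on that aromatic carbon would move the number of compound 3.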